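Ring Growth on the Acyl Group in an Amine-Substituted Series

The source may hold more compounds than are shown below. What is called first, only, known or untested is meant among the compounds shown, and "the series" means these compounds.

Compound 1 `Cc1[nH]nc(N)c1-c1cccc(Cl)c1`, compound 2 `CC(=O)n1nc(C)c(-c2ccc(Cl)c(Cl)c2)c1N` and compound 3 `Cc1nn(C(=O)C2CC2)c(N)c1-c1ccc(Cl)c(Cl)c1` have been measured; compound 4 `Cc1nn(C(=O)C2CCCC2)c(N)c1-c1ccc(Cl)c(Cl)c1` has not.

In an assay on Sf9 cells for inhibition of mitogen-activated protein kinase kinase kinase 14 (Homo sapiens), read by ADP-Glo, with a stated time of 60 min (a lower number here means a stronger inhibitor, a higher number a weaker inhibitor), compound 1 reaches only a limit, > 100000 nM. Compound 2 gives 8400 nM in this assay. Compound 3 gives 24300 nM in this assay, the highest of the two numbers, its nearest neighbour being compound 2. Among the measured compounds shown here, the one measured step, a 2.9-fold higher number from compound 2 to compound 3 (0.46 log units; beyond the scatter), came with the cyclopropyl in place of methyl on the carbonyl carbon. Compound 4 carries cyclopentyl in place of cyclopropyl on a carbonyl carbon. That earlier step bears on this one, as both enlarge the group on the carbonyl carbon. A further rise of similar size is expected, a 1.9-fold higher number from compound 3 to compound 4 (0.27 log units; within the scatter). Compound 4 is therefore estimated at 45000 nM in this assay, between 15000 nM and 120000 nM.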

Compound 4, half-maximal inhibitory concentration: 41000 nM
For compound 4 the middle estimate is 1.1-fold (0.04 log units) above the measured one, within the range that was stated.
By their numbers in this assay, from the lowest: compound 2; then compounds 3 and 4 (each within the scatter of the next). At a limit, above all of these: compound 1.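

Changing cyclopropyl to cyclopentyl on the carbonyl carbon gives a 1.7-fold higher number from compound 3 to compound 4 (0.23 log units; within the scatter), so this further ring growth, unlike the step from methyl to cyclopropyl, does not separate the two compounds. Across the whole span from methyl to cyclopentyl the difference stands clear, at a 4.9-fold higher number from compound 2 to compound 4 (0.69 log units; beyond the scatter). Compound 1 alone remains at a limit, which compound 4 does not reach: the limit of > 100000 nM in this assay, at which 1 of the 4 values shown sits.

From the compounds shown here alone, whether an amine, a carboxylic acid or a phenyl group on the carbonyl carbon would give a lower number than compound 2 stays open. So does the effect of the acyl group alone, since compound 1 differs from compound 2 in more than one place.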